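A New Aromatic Group on a Shared Core

The source may report more compounds than this note shows. Statements on the series, on what has been measured and on what is new or still open speak of the compounds shown alone.

Compound 3 `COc1cc(Br)ccc1Nc1cc(NC(=O)Nc2c(Cl)cccc2Cl)ncn1` gives 29.1% in a functional assay on NCI-H520 cells (Homo sapiens) for inhibition, read by MTT assay, with a stated time of 48 h, tested at 10 uM (a lower number here means less inhibition, a higher number more inhibition at the concentration tested (going by the name of the read-out)), the second highest of three measured numbers. Compound 1 `Cc1ccc(Nc2cc(NC(=O)Nc3c(Cl)cccc3Cl)ncn2)cc1C` gives 47.5%, while compound 2 `COc1cc(NC(=O)Nc2cc(Nc3ccc(F)c(Cl)c3)ncn2)cc(OC)c1` gives 25.5%, a value within the scatter of compound 3. The unmeasured compound 4 `O=C(Nc1cc(Nc2ccc(F)c(Cl)c2)ncn1)Nc1c(Cl)cccc1Cl` carries 3-chloro-4-fluorophenyl in place of 4-bromo-2-methoxyphenyl on a nitrogen on an aromatic ring. One earlier step bears on this, an exchange at the same nitrogen: a number 18.4 percentage points lower from compound 1 to compound 3 (beyond the scatter). Compound 2 shares the 3-chloro-4-fluorophenyl group of compound 4 but differs elsewhere in the molecule, so its value only shows that this group appears together with low inhibition. A small step is therefore expected, a number 0.9 percentage points higher from compound 3 to compound 4 (within the scatter). Compound 4 is expected to give 30%, within a range from 15% to 45%.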

Compound 4, a percentage reported as inhibition, at one concentration (the size of the read-out at that concentration, not a potency): 39.5%
Estimate against measurement, compound 4: 9.5 percentage points below, within the range that was stated.
By their numbers in this assay, from the lowest: compounds 2 and 3 (each within the scatter of the next); then compounds 4 and 1 (each within the scatter of the next).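

With the rest of the molecule unchanged, 3-chloro-4-fluorophenyl in place of 4-bromo-2-methoxyphenyl gives a number 10.4 percentage points higher from compound 3 to compound 4 (beyond the scatter) in this assay and so shows that the number at this nitrogen can also rise with a change of group. Set against 3,4-dimethylphenyl, the same group gives a number 8 percentage points lower from compound 1 to compound 4 (within the scatter) and so these two groups stand level, with only 4-bromo-2-methoxyphenyl apart from both. No measurement at hand explains this difference. As far as these compounds go, it remains open whether the bromine or the methoxy group of 4-bromo-2-methoxyphenyl accounts for the lower number of compound 3, and what a piperidine or pyridine ring would give on this nitrogen.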